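Compound 2 to compound 3: methoxy to hydroxy

This account rests on a few compounds, and the source may have more. Where it says the series, first, only, none or still open, it means among the compounds named here.

Of the compounds shown here, two have numbers so far. In an ADME assay on NHDF cells (Homo sapiens) for cytotoxicity, read by MTT assay, with a stated time of 72 h (a lower number here means a stronger inhibitor, a higher number a weaker inhibitor), compound 1 `COc1cccc(/C=C2\CCC/C(=C\c3cccc(Br)c3)C2=O)c1OC` gives 23900 nM and compound 2 `COc1ccc(/C=C2\CCC/C(=C\c3cccc(OC)c3OC)C2=O)cc1OC` gives 14900 nM with no separation from compound 1 beyond the scatter. Compound 2 therefore cannot be ranked against compound 1 on these numbers.

Compound 3 `COc1cc(/C=C2\CCC/C(=C\c3cccc(OC)c3OC)C2=O)ccc1O` keeps the core of compound 2 and carries a single change hydrogen in place of methyl on an oxygen on an aromatic ring in which hydrogen takes the place of methyl on an oxygen on an aromatic ring, so that methoxy becomes hydroxy. For the measured compounds named here, no measured pair shows this change, so there is no direct precedent for it. The narrow spread between compound 1 at 23900 nM and compound 2 at 14900 nM gives no ground for expecting a large move. In this assay a small shift toward a lower number is expected, one that stays within the scatter. The estimated step of a 1.2-fold lower number from compound 2 to compound 3 (0.09 log units; within the scatter) is expected to be of that modest size. For compound 3 the expected value is 12000 nM with an estimated range of 5000 nM to 28000 nM in this measurement.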

Compound 3, half-maximal inhibitory concentration: 14300 nM
Estimate against measurement, compound 3: 1.2-fold (0.08 log units) below, within the range that was stated.
By their numbers in this assay, from the lowest: compounds 3, 2 and 1 (each within the scatter of the next).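

In this assay, for the compounds shown here, the step of a 1.0-fold lower number from compound 2 to compound 3 (0.02 log units; within the scatter) is the first reading of a single change, and it lies within the scatter: with hydrogen in place of methyl on an oxygen on an aromatic ring, methoxy and hydroxy cannot be told apart at this position. The step of a 1.7-fold lower number from compound 1 to compound 3 (0.22 log units; within the scatter) carries a larger exchange, 4-hydroxy-3-methoxyphenyl in place of 3-bromophenyl on a double-bonded chain carbon bound to a double-bonded ring carbon, and it too lies within the scatter, so compounds 1, 2 and 3 remain unranked in this assay. Nothing available here bears on the reason for either result.

Open, from the compounds shown here alone, is whether this position stays equally flat with a group of another kind on the oxygen, such as a longer chain in place of methyl, or with an amine or a carboxylic acid in place of the hydroxy. A single pair also leaves open whether the same methoxy to hydroxy change reads the same way on the other aromatic ring of the shared core.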